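This account rests on a few compounds, and the source may have more. Where it says the series, first, only, none or still open, it means among the compounds named here.

Measured so far:
compound 1 `Nc1ccccc1/C=C/c1ccccc1O`: 27 ug/mL
compound 2 `COc1ccccc1/C=C/c1ccccc1O`: 15 ug/mL
compound 3 `Nc1cccc(/C=C/c2ccccc2O)c1`: 96 ug/mL

All values come from an ADME assay on HEK293 cells (Homo sapiens) for inhibition, read by MTT assay, with a stated time of 2 days; on this read-out lower numbers stand for stronger inhibition and higher numbers for weaker inhibition. Compound 1 and compound 2 differ in one place, (methoxy in place of amino on an aromatic carbon), and the step is a 1.8-fold lower number from compound 1 to compound 2 (0.26 log units; within the scatter). Compound 3 has the same atoms as compound 1, joined differently; the difference between the two cores is not broken down here. In this assay compound 3 gives the highest of the three numbers, its gap to compound 1 and to compound 2 each beyond the scatter.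

Compound 4 `COc1cccc(/C=C/c2ccccc2O)c1` is not yet measured. It differs from compound 3 by methoxy in place of amino on an aromatic carbon. This is the same kind of change as in the first pair, but the place is not the same: there the group sits ortho to a group of 9 heavy atoms, here meta to a group of 9 heavy atoms. Among the compounds with values here, only one measured example of this change exists, so the expectation rests on it alone. The expected step is a 1.7-fold lower number from compound 3 to compound 4 (0.24 log units; within the scatter), in line with a 1.8-fold lower number from compound 1 to compound 2 (0.26 log units; within the scatter). Compound 4 is therefore estimated at 55 ug/mL, with a likely range from 25 ug/mL to 130 ug/mL.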

Compound 4, half-maximal inhibitory concentration: 20 ug/mL
The estimate for compound 4 lay 2.8-fold (0.44 log units) above the measured number; measured number outside the range, below it.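

In this assay, methoxy in place of amino gives a 4.8-fold lower number from compound 3 to compound 4 (0.68 log units; beyond the scatter), so this change does not carry over between the two cores at a fixed size: the same change on two cores in this assay, a 1.8-fold lower number (0.26 log units; within the scatter) from compound 1 to compound 2 and a 4.8-fold lower number (0.68 log units; beyond the scatter) from compound 3 to compound 4, 2.7-fold (0.43 log units) apart, beyond the scatter of two such steps. Only on the core of compound 3 does the step stand clear of the scatter. These two pairs show that the size of the step differs with the core, but not which feature of the core sets it, and they give no basis for predicting the step on a further core.

On these data alone, it remains open how other groups, such as fluorine, nitrile or a longer alkoxy chain, would behave on these two cores. As far as these compounds go, it is also open whether the gap between the cores would persist with them.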